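From 4-Chlorophenyl to 3-Nitrophenyl on a Shared Core

The compounds below may be only part of what the source reports. "The series", "measured", "known", "first", "only" and "open" are said of these compounds alone.

Of the compounds shown here, two built on a shared core have been measured so far in a functional assay on HepG2 cells (Homo sapiens) for cytotoxicity, read by MTT assay, with a stated time of 24 h; on this read-out higher numbers stand for weaker inhibition and lower numbers for stronger inhibition. Compound 1 (`COc1cc(/C=C2\CN(C)C/C(=C\c3cccc([N+](=O)[O-])c3)C2=O)cc(OC)c1`) gives 1840 nM. Compound 2 (`COc1cc(/C=C2\CN(C)C/C(=C\c3ccc(Cl)cc3)C2=O)cc(OC)c1OC`) gives 8250 nM, the higher of the two numbers and so the weaker inhibition, and its gap to compound 1 lies beyond the scatter.

Compound 3 (`COc1cc(/C=C2\CN(C)C/C(=C\c3cccc([N+](=O)[O-])c3)C2=O)cc(OC)c1OC`) has not yet been measured. It differs from compound 2 in one place, with 3-nitrophenyl in place of 4-chlorophenyl on a double-bonded chain carbon bound to a double-bonded ring carbon. Among the measured compounds shown here, no measured pair shows this change on its own, so any forecast is uncertain. For the measured compounds named here, the only measured guide is compound 1, which also bears 3-nitrophenyl and stands at 1840 nM. On that basis, a moderate step of a 2.8-fold lower number from compound 2 to compound 3 (0.44 log units; beyond the scatter) is expected in this assay, towards stronger inhibition and probably beyond the scatter. The estimated value for compound 3 is 3000 nM, with an expected range of 1100 nM to 8000 nM.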

Compound 3, half-maximal inhibitory concentration: 1890 nM
Estimate against measurement, compound 3: 1.6-fold (0.20 log units) above; the measured number falls inside the stated range.
By their numbers in this assay, from the lowest: compounds 1 and 3 (each within the scatter of the next); then compound 2.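

Among the compounds shown here, with the two compounds measured earlier differing in more than one place, compound 3 gives the first reading of a single change at this position: in this assay, 3-nitrophenyl in place of 4-chlorophenyl on a double-bonded chain carbon bound to a double-bonded ring carbon gives a 4.4-fold lower number from compound 2 to compound 3 (0.64 log units; beyond the scatter), towards stronger inhibition, with the rest of the structure unchanged. For the compounds shown here, it also gives the first reading of a second site, where methoxy in place of hydrogen on an aromatic carbon gives a 1.0-fold higher number from compound 1 to compound 3 (0.01 log units; within the scatter), so that change shows no effect that can be told from the scatter in this 3-nitrophenyl series. Going by these compounds alone, of the two single changes now available, only the one at the double-bonded chain carbon moves the number beyond the scatter.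

This single pair cannot separate the gain of 3-nitrophenyl from the loss of 4-chlorophenyl, and it leaves open how an aminophenyl or a carboxyphenyl group would read at the same place. Nothing in the data shown explains the step at this position.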